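Replacing the whole amide side chain by an amino group

The source may report more compounds than this note shows. Statements on the series, on what has been measured and on what is new or still open speak of the compounds shown alone.

Compound 3 `COc1cc2cc(C(=O)NCCCc3ccccc3)c(=O)oc2cc1OCCCOc1no[n+]([O-])c1S(=O)(=O)c1ccccc1` gives 760 nM in a functional assay on MDA-MB-231 cells (Homo sapiens) for inhibition, read by MTT assay, with a stated time of 48 h (a higher number here means a weaker inhibitor, a lower number a stronger inhibitor), and sits at the low end of three numbers that all lie within the scatter of one another. Compound 1 `COc1cc2cc(C(=O)NCc3ccc(F)cc3)c(=O)oc2cc1OCCCOc1no[n+]([O-])c1S(=O)(=O)c1ccccc1` gives 770 nM and compound 2 `COc1cc2cc(C(=O)Nc3ccccc3)c(=O)oc2cc1OCCCOc1no[n+]([O-])c1S(=O)(=O)c1ccccc1` gives 1190 nM; the steps of a 1.0-fold lower number from compound 1 to compound 3 (0.01 log units; within the scatter), a 1.6-fold lower number from compound 2 to compound 3 (0.19 log units; within the scatter) and a 1.5-fold higher number from compound 1 to compound 2 (0.19 log units; within the scatter) stay within the scatter. Compound 4 `COc1cc2cc(N)c(=O)oc2cc1OCCCOc1no[n+]([O-])c1S(=O)(=O)c1ccccc1` carries amino in place of (3-phenylpropyl)carbamoyl on an aromatic carbon. The three measured steps only exchanged the group on the amide nitrogen, so none of them bears on removing the entire (3-phenylpropyl)carbamoyl group; that change lies outside what the measured compounds show. A step of uncertain size, leaning towards a higher number, is therefore expected as a 2.0-fold higher number from compound 3 to compound 4 (0.30 log units; within the scatter). Compound 4 is estimated at 1500 nM, with a range from 500 nM to 5000 nM.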

Compound 4, half-maximal inhibitory concentration: 1390 nM
Beside the measured number, compound 4's estimate is 1.1-fold (0.03 log units) above it; measured number inside the range.
By their numbers in this assay, from the lowest: compounds 3, 1, 2 and 4 (each within the scatter of the next).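

In this assay, replacing the amide side chain with amino stays within the scatter for each group removed: the (3-phenylpropyl)carbamoyl group (a 1.8-fold higher number from compound 3 to compound 4 (0.26 log units; within the scatter)), the phenylcarbamoyl group (a 1.2-fold higher number from compound 2 to compound 4 (0.07 log units; within the scatter)) and the (4-fluorobenzyl)carbamoyl group (a 1.8-fold higher number from compound 1 to compound 4 (0.26 log units; within the scatter)). The earlier swaps kept the carbonyl and amide nitrogen, whereas these steps show that a number in this range does not depend on keeping the whole amide on this aromatic carbon. No measurement shown explains this result. Going by these compounds, whether a carboxylic acid or a methyl group on this aromatic carbon would stay within the scatter remains open.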